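Swapping the Aryl Group of Compound 3

A few compounds are considered here, and "the series" means these few. Any claim that something is new, unique, unknown or untested is made for them only; others in the source may bear on it.

Compound 1, `COc1ccc(/C=C(\C)C(=O)/C=C/c2ccc(/C=C/C(=O)/C(C)=C/c3ccc(OC)cc3)cc2)cc1`: 460000 nM
Compound 2, `CC/C(=C\c1ccc(Cl)cc1)C(=O)/C=C/c1ccc(Cl)cc1`: 28300 nM
Compound 3, `COc1ccc(/C=C(\C)C(=O)/C=C/c2ccc(Cl)cc2)cc1`: 87000 nM

All three were measured in an ADME assay on Vero cells (Chlorocebus sabaeus) for cytotoxicity, read by MTT assay, with a stated time of 72 h; a lower number here means that less compound is tolerated, a higher number that more compound is tolerated. Compound 3 stands second highest of the three numbers; its nearest neighbour is compound 2, with a lower number, and compound 1 lies furthest from it, with a higher number, both gaps beyond the scatter. Compound 4, `COc1ccc(/C=C(\C)C(=O)/C=C/c2ccccc2F)cc1`, is not yet measured in this assay. It differs from compound 3 in one place: 2-fluorophenyl in place of 4-chlorophenyl on a double-bonded chain carbon bound to a double-bonded chain carbon. Within the data shown here, no pair of measured compounds shows a step of this kind, so its size cannot be read from the data. The expected step is a 1.4-fold higher number from compound 3 to compound 4 (0.14 log units; within the scatter), a modest rise, hardly beyond the scatter. Compound 4 is estimated at 120000 nM, within a range from 45000 nM to 320000 nM.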

Compound 4, half-maximal cytotoxic concentration: 81200 nM
For compound 4 the middle estimate is 1.5-fold (0.17 log units) above the measured one, within the range that was stated.
By their numbers in this assay, from the lowest: compound 2; then compounds 4 and 3 (each within the scatter of the next); then compound 1.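

In this assay, among these compounds, the change to 2-fluorophenyl from 4-chlorophenyl gives a 1.1-fold lower number from compound 3 to compound 4 (0.03 log units; within the scatter) and so provides the first readable step at this place, where the earlier compounds offered none. Within the scatter, the two aryl groups cannot be told apart here, although the single step alters both the halogen and its ring position. Nothing available explains why the two compounds read alike. The compounds shown leave open whether 2-chlorophenyl or 4-fluorophenyl would read the same. They also leave open how an amine, a carboxylic acid or a longer chain would read at this place.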